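Swapping Hydroxy for Chloro on a Urea-Linked Phenyl Ring

The source may report more compounds than this note shows. Statements on the series, on what has been measured and on what is new or still open speak of the compounds shown alone.

Compound 1 `COc1cc(NC(C)CCCNC(=O)Nc2ccc(O)cc2)c2ncccc2c1` gives 21000 nM in a functional assay on MOLT-4 cells (Homo sapiens) for inhibition, read by MTT assay, with a stated time of 72 h (on this read-out higher numbers stand for weaker inhibition and lower numbers for stronger inhibition), the lowest of three numbers, though none of the gaps exceeds the scatter. Compound 2 `COc1cc(NC(C)CCCNC(=O)Nc2cccc(F)c2)c2ncccc2c1` gives 23000 nM and compound 3 `COc1cc(NC(C)CCCNC(=O)Nc2ccc(Br)cc2)c2ncccc2c1` gives 25000 nM. The steps of a 1.1-fold higher number from compound 1 to compound 2 (0.04 log units; within the scatter) and a 1.2-fold higher number from compound 1 to compound 3 (0.08 log units; within the scatter) are both within the scatter, as is a 1.1-fold higher number from compound 2 to compound 3 (0.04 log units; within the scatter). Compound 4 `COc1cc(NC(C)CCCNC(=O)Nc2ccc(Cl)cc2)c2ncccc2c1` differs from compound 1 in one place: chloro in place of hydroxy on an aromatic carbon. For the measured compounds named here, the closest precedent is the step to compound 3, where bromo replaced hydroxy on the same aromatic carbon without a change beyond the scatter; the move to compound 2 points the same way. Compound 4 is therefore expected to show no step beyond the scatter, a 1.1-fold higher number from compound 1 to compound 4 (0.06 log units; within the scatter). The estimate for compound 4 is 24000 nM, in the range 12000 nM to 48000 nM.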

Compound 4, half-maximal inhibitory concentration: 24000 nM
For compound 4 middle estimate and measured number coincide at the digits printed; low and high end bracket the measured number.
By their numbers in this assay, from the lowest: compounds 1, 2, 4 and 3 (each within the scatter of the next).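

In this assay, chloro in place of hydroxy removes a hydrogen-bond donor and a hydrogen-bond acceptor from the 4-hydroxyphenyl group, yet it gives a 1.1-fold higher number from compound 1 to compound 4 (0.06 log units; within the scatter) and so leaves the number within the scatter. Chloro in place of bromo gives a 1.0-fold lower number from compound 3 to compound 4 (0.02 log units; within the scatter) and 4-chlorophenyl in place of 3-fluorophenyl gives a 1.0-fold higher number from compound 2 to compound 4 (0.02 log units; within the scatter) in the same way, so all four compounds remain within the scatter of one another at this ring. No measurement at hand bears on this result. On these data alone, what stays open is whether an amine or a carboxylic acid at this place would move the number beyond the scatter. Also open, as far as these compounds go, is whether changing the chain that carries the urea would do so.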